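A few compounds are considered here, and "the series" means these few. Any claim that something is new, unique, unknown or untested is made for them only; others in the source may bear on it.

In an assay on isolated protein for inhibition of complement C1r subcomponent (Homo sapiens) (a lower number here means a stronger inhibitor, a higher number a weaker inhibitor), compound 1 `O=c1oc(-c2ccccc2I)nc2ccccc12` gives 16700 nM. Compound 2 `Cc1ccc2c(=O)oc(-c3ccccc3I)nc2c1` reaches the limit of this assay, > 62500 nM, which is a boundary rather than a number. Compound 3 `COc1ccc2c(=O)oc(-c3ccccc3I)nc2c1` likewise sits at the limit, > 62500 nM, so its standing is known only as a boundary. Two of the three values shown share that boundary, as the limit of > 62500 nM in this assay, at which 2 of the 3 values shown sit, records. The step of an at least 3.7-fold higher number from compound 1 to compound 2 (0.57 log units; beyond the scatter) shows that a methyl in place of hydrogen at this spot weakens inhibition, and an at least 3.7-fold higher number from compound 1 to compound 3 (0.57 log units; beyond the scatter) shows the same for a methoxy. The step that the two limits leave unreadable from compound 2 to compound 3 cannot be sized, both ends being limits.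

Compound 4 `O=c1oc(-c2ccccc2I)nc2cc([N+](=O)[O-])ccc12` differs from compound 3 by nitro in place of methoxy on an aromatic carbon. Among the measured compounds shown here, no measured compound carries a nitro, so the bearing evidence is only that two different groups at this position, methyl and methoxy, both pushed the number past the limit. The step of an at least 1.0-fold lower number from compound 3 to compound 4 (0.01 log units; that floor lies within the scatter) is therefore expected to be none beyond the scatter, with compound 4 staying weak. Compound 4 is estimated at 60000 nM, between 15000 nM and 250000 nM, with a fair chance that this assay again reports only a limit.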

Compound 4, half-maximal inhibitory concentration: 22000 nM
Compound 4: the middle estimate sits 2.7-fold (0.44 log units) above what was measured, and the stated range covers the measured number.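

This position on the aromatic ring is not closed to every added group: in this assay, nitro in place of methoxy gives an at least 2.8-fold lower number from compound 3 to compound 4 (0.45 log units; beyond the scatter), and nitro in place of methyl gives an at least 2.8-fold lower number from compound 2 to compound 4 (0.45 log units; beyond the scatter). Both steps are only minimum sizes, since compound 2 and compound 3 are known only as limits: the limit of > 62500 nM in this assay, at which 2 of the 4 values shown sit.

Set against compound 1, which carries hydrogen at this position, nitro gives a 1.3-fold higher number from compound 1 to compound 4 (0.12 log units; within the scatter), so compound 1 and compound 4 cannot be told apart, and the loss seen with methyl and methoxy does not extend to every group placed here.

The compounds shown leave open why nitro parts company with methyl and methoxy, and whether an amine, a carboxylic acid or a chlorine at this position would behave like nitro or like the other two. They also leave open whether the same groups would give the same result on the other carbons of this ring.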